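From fluoro to methoxy in compound 2

The compounds below may be only part of what the source reports. "The series", "measured", "known", "first", "only" and "open" are said of these compounds alone.

- Compound 1 `O=C(/C=C\Nc1ccc(F)cc1)c1cn(-c2ccccc2)nc1-c1ccc(F)cc1`: 6500 nM
- Compound 2 `O=C(/C=C\Nc1ccc(C(F)(F)F)cc1)c1cn(-c2ccccc2)nc1-c1ccc(F)cc1`: > 50000 nM (a limit)
- Compound 3 `COc1ccc(N/C=C\C(=O)c2cn(-c3ccccc3)nc2-c2ccc(F)cc2)cc1`: 3200 nM

All three values come from a functional assay on HT-29 cells (Homo sapiens) for antiproliferative activity, read by MTT assay, with a stated time of 48 h; a lower number here means a stronger inhibitor, a higher number a weaker inhibitor. Going by these compounds, compound 2 shows only (the limit of > 50000 nM in this assay, at which 1 of the 3 values shown sits), so its true value is unknown. Compound 4 `COc1ccc(-c2nn(-c3ccccc3)cc2C(=O)/C=C\Nc2ccc(C(F)(F)F)cc2)cc1` differs from compound 2 in one place: methoxy in place of fluoro on an aromatic carbon. Here 4-fluorophenyl becomes 4-methoxyphenyl, with methoxy in place of fluoro on an aromatic carbon, para to a large group.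

The nearest guide is the same swap made elsewhere in the molecule, which gave a 2.0-fold lower number from compound 1 to compound 3 (0.31 log units; beyond the scatter). The other two steps, an at least 7.6-fold higher number from compound 1 to compound 2 (0.88 log units; beyond the scatter) and an at least 15-fold lower number from compound 2 to compound 3 (1.19 log units; beyond the scatter), are larger, but both change the trifluoromethyl group, which compound 4 keeps. They therefore bear on this change only indirectly. Going by compound 3 at 3200 nM, a modest step to a lower number is expected in this assay, though this swap has not been measured at the new place. Since the starting point is a limit, compound 4 may also end up reported only as a limit. The expected change is an at least 1.2-fold lower number from compound 2 to compound 4 (0.09 log units; that floor lies within the scatter). For compound 4 the estimated value is 40000 nM, with an expected range of 10000 nM to 90000 nM.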

Compound 4, half-maximal inhibitory concentration: 9870 nM
Beside the measured number, compound 4's estimate is 4.1-fold (0.61 log units) above it, outside the stated range (below it).
By their numbers in this assay, from the lowest: compound 3; then compounds 1 and 4 (each within the scatter of the next). At a limit, above all of these: compound 2.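

In this assay, replacing 4-fluorophenyl with 4-methoxyphenyl while the trifluoromethyl group stays in place gives an at least 5.0-fold lower number from compound 2 to compound 4 (0.70 log units; beyond the scatter), which shows that this position also responds to the swap and that a compound carrying trifluoromethyl can give a measured number rather than a limit. The entry for compound 2, > 50000 nM, is a limit and not a number, so only the smallest possible size of this step is known. Among the compounds shown, methoxy in place of fluoro now lowers the number at two different places, but the size of the effect cannot be compared between them: the same change on two cores in this assay, a 2.0-fold lower number (0.31 log units; beyond the scatter) from compound 1 to compound 3 and an at least 5.0-fold lower number (0.70 log units; beyond the scatter) from compound 2 to compound 4; the limit leaves it open whether they differ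

The compounds shown leave open whether this response is particular to methoxy or would also appear with another group on this aromatic carbon, such as an amine, a hydroxyl or a longer ethoxy chain. They also leave open what this assay would report for a molecule carrying methoxy at both of the places tested here.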